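A Large Aromatic Group in Place of Hydroxymethyl

A few compounds are considered here, and "the series" means these few. Any claim that something is new, unique, unknown or untested is made for them only; others in the source may bear on it.

Measured compounds:
Compound 1, `C=C[C@@](C)(/C=C/c1ccc(O)cc1)CCC(O)C(C)(C)O`: in a functional assay on SEM cells (Homo sapiens) for cytotoxicity, with a stated time of 72 h (on this read-out lower numbers stand for an effect already at smaller amounts and higher numbers for an effect only at larger amounts of compound), compound 1 gives > 36600 nM, which is a limit of the assay.
Compound 2, `C=C[C@@](C)(/C=C/c1ccc(O)cc1)CC/C=C(C)/C=N/N`: in this assay compound 2 gives > 36600 nM, also a limit.
Compound 3, `C=C[C@@](C)(/C=C/c1ccc(O)c(CO)c1)CCC=C(C)C`: in this assay compound 3 gives > 36600 nM, again a limit.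

Compound 3 thus stands where every measured compound stands, at the limit of > 36600 nM in this assay, at which 3 of the 3 values shown sit; no number has been read for any of them. Among the measured compounds shown here, the one measured step, a step that the two limits leave unreadable from compound 1 to compound 2, cannot be sized because the limit of > 36600 nM in this assay, at which 3 of the 3 values shown sit, holds both of its compounds.

Compound 4, `C=C[C@@](C)(/C=C/c1ccc(O)c(/C=C/c2ccc(Cl)cc2)c1)CCC=C(C)C`, has not been measured. It differs from compound 3 by 2-(4-chlorophenyl)ethenyl in place of hydroxymethyl on an aromatic carbon. For the measured compounds named here, no measured step touches this part of the shared core, and the single measured step is itself unreadable, so the data give neither a size nor a direction for the change. Compound 4 is expected to give 20000 nM in this assay, within an estimated range from 4000 nM to 80000 nM, with a real chance that only a limit is reported again. Going by the values given here, this estimate means an expected step of an at least 1.8-fold lower number from compound 3 to compound 4 (0.26 log units; that floor lies within the scatter), which no measured step supports or contradicts.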

Compound 4, half-maximal effective concentration: > 36600 nM
Compound 4: only a limit was reported; the forecaster's own chance of this, stated with the estimate: 55%; at least 1.8-fold (0.26 log units) between middle value and limit.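

No step can be read between compound 3 and compound 4, because both sit at a limit rather than at a number: the limit of > 36600 nM in this assay, at which 4 of the 4 values shown sit.

The compounds shown leave open which change to the shared core, if any, would give a readable number in this assay.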